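Replacing the aryl ethenyl group of compound 3 with methyl

A few compounds are considered here, and "the series" means these few. Any claim that something is new, unique, unknown or untested is made for them only; others in the source may bear on it.

Three esters on a shared core have been measured in a functional assay on K562 cells (Homo sapiens) for antiproliferative activity, read by MTT assay, with a stated time of 6 days; a higher number here means a weaker inhibitor, a lower number a stronger inhibitor: compound 1 (`O=C1C=C[C@@H](OCc2ccccc2)[C@@H]([C@@H](COC(=O)/C=C/c2ccccc2)OCc2ccccc2)O1`) gives 1590 nM, compound 2 (`COc1ccc(/C=C/C(=O)OC[C@@H](OCc2ccccc2)[C@H]2OC(=O)C=C[C@H]2OCc2ccccc2)cc1`) gives 430 nM and compound 3 (`O=C1C=C[C@@H](OCc2ccccc2)[C@@H]([C@@H](COC(=O)/C=C/c2ccc(F)cc2)OCc2ccccc2)O1`) gives 1010 nM. Compound 3 cannot be separated from its unsubstituted parent, with a 1.6-fold lower number from compound 1 to compound 3 (0.20 log units; within the scatter), which lies within the scatter. Compound 2 is the strongest of the three, and a 2.3-fold higher number from compound 2 to compound 3 (0.37 log units; beyond the scatter) is a modest step beyond the scatter.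

Compound 4 (`CC(=O)OC[C@@H](OCc1ccccc1)[C@H]1OC(=O)C=C[C@H]1OCc1ccccc1`) is the next entry. The change is methyl in place of 2-(4-fluorophenyl)ethenyl on a carbonyl carbon, giving an acetoxy group. The measured steps only exchange a substituent on the aromatic ring, and the largest is a 3.7-fold lower number from compound 1 to compound 2 (0.57 log units; beyond the scatter). For the measured compounds named here, that step shows that the number can move with a change on this ring, but no measured compound lacks the ring, so the evidence for this larger change is indirect. A modest loss is expected, held with low confidence: the expected step is a 2.2-fold higher number from compound 3 to compound 4 (0.34 log units; beyond the scatter) in this assay. For compound 4 the estimate is 2200 nM, with an expected range of 600 nM to 7000 nM.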

Compound 4, half-maximal inhibitory concentration: 880 nM
Compound 4: middle estimate off by 2.5-fold (0.40 log units), on the high side; the range from low to high includes it.
By their numbers in this assay, from the lowest: compound 2; then compounds 4, 3 and 1 (each within the scatter of the next).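

In this assay, the step of a 1.1-fold lower number from compound 3 to compound 4 (0.06 log units; within the scatter) lies within the scatter, as does a 1.8-fold lower number from compound 1 to compound 4 (0.26 log units; within the scatter), so at this carbonyl carbon a lone methyl cannot be told apart from either the 2-(4-fluorophenyl)ethenyl or the 2-phenylethenyl group. The earlier compounds shown here only varied a substituent on the aromatic ring, whereas this result shows that the whole aryl ethenyl group can leave without a change that can be read against these two esters. Only the methoxy-bearing ester separates from the acetoxy compound, with a 2.0-fold higher number from compound 2 to compound 4 (0.31 log units; beyond the scatter) as a modest step, and no measurement at hand accounts for that difference.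

From the compounds shown here alone, it remains open whether a free hydroxyl in place of the acetoxy group, or a longer chain such as propanoyl or butanoyl on the same carbonyl carbon, would stay close to compound 4. Also open, going by these compounds, is whether the edge of compound 2 carries over to a saturated 2-(4-methoxyphenyl)ethyl group or to an amine such as dimethylamino on the aromatic ring.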